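This account rests on a few compounds, and the source may have more. Where it says the series, first, only, none or still open, it means among the compounds named here.

Measured in a functional assay on A549 cells (Homo sapiens) for antiproliferative activity, read by MTT assay, with a stated time of 48 h; a lower number here means a stronger inhibitor, a higher number a weaker inhibitor:
- compound 1 `COc1ccc(-c2cc3c(cn2)[nH]c(=O)n3-c2cc(OC)c(OC)c(OC)c2)cc1F`: 2020 nM
- compound 2 `CCOc1ccc(-c2cc3c(cn2)[nH]c(=O)n3-c2cc(OC)c(OC)c(OC)c2)cc1`: 5300 nM
- compound 3 `COc1ccc(-c2cc3c([nH]c(=O)n3-c3cc(OC)c(OC)c(OC)c3)c(C(N)=O)n2)cc1F`: 380 nM

Among these three, compound 3 gives the lowest number, 380 nM. Compound 4 `CCOc1ccc(-c2cc3c([nH]c(=O)n3-c3cc(OC)c(OC)c(OC)c3)c(C(N)=O)n2)cc1` has not yet been measured. It differs from compound 3 by 4-ethoxyphenyl in place of 3-fluoro-4-methoxyphenyl on an aromatic carbon. The same exchange was measured once, without the carbamoyl group, as a 2.6-fold higher number from compound 1 to compound 2 (0.42 log units; beyond the scatter), a modest step. Adding the carbamoyl group gave a 5.3-fold lower number from compound 1 to compound 3 (0.73 log units; beyond the scatter), also modest. If the two changes simply add, a modest rise is expected in this assay, though this single pair is the only support. The expected change is a 2.6-fold higher number from compound 3 to compound 4 (0.42 log units; beyond the scatter). Compound 4 is estimated at 1000 nM, with an expected range of 450 nM to 2300 nM.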

Compound 4, half-maximal inhibitory concentration: 20700 nM
Beside the measured number, compound 4's estimate is 21-fold (1.32 log units) below it, and the stated range ends below it.
By their numbers in this assay, from the lowest: compound 3; then compound 1; then compound 2; then compound 4.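

In this assay, the exchange of 3-fluoro-4-methoxyphenyl for 4-ethoxyphenyl weighs far more with the carbamoyl group present, a 54-fold higher number from compound 3 to compound 4 (1.74 log units; beyond the scatter), so the two changes do not simply add: the same change on two cores in this assay, a 2.6-fold higher number (0.42 log units; beyond the scatter) from compound 1 to compound 2 and a 54-fold higher number (1.74 log units; beyond the scatter) from compound 3 to compound 4, 21-fold (1.32 log units) apart, beyond the scatter of two such steps. The carbamoyl group also changes direction with the aryl group, lowering the number with 3-fluoro-4-methoxyphenyl but giving a 3.9-fold higher number from compound 2 to compound 4 (0.59 log units; beyond the scatter) with 4-ethoxyphenyl: the same change on two cores in this assay, a 5.3-fold lower number (0.73 log units; beyond the scatter) from compound 1 to compound 3 and a 3.9-fold higher number (0.59 log units; beyond the scatter) from compound 2 to compound 4, 21-fold (1.32 log units) apart, beyond the scatter of two such steps.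

On these data alone, it remains open whether the fluorine or the ethoxy chain drives this dependence, which a 4-methoxyphenyl or 3-fluoro-4-ethoxyphenyl group could help separate. As far as these compounds go, whether a carboxylic acid at the carbamoyl position would behave alike also remains open.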